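The compounds below may be only part of what the source reports. "The series", "measured", "known", "first", "only" and "open" are said of these compounds alone.

Working notes on the shared core of compound 1 `CCOC(=O)c1c(C)[nH]c(=O)c(C#N)c1-c1ccccc1`, compound 2 `CCOC(=O)c1c(C)[nH]c(=O)c(C#N)c1-c1ccc(C)cc1` and compound 3 `CCOC(=O)c1c(C)[nH]c(=O)c(C#N)c1-c1ccc(Br)cc1`. In an ADME assay on MRC5 cells (Homo sapiens) for cytotoxicity, read by MTT assay, with a stated time of 24 h (a higher number here means a weaker inhibitor, a lower number a stronger inhibitor), compound 1 gives 220000 nM, compound 2 gives 438000 nM and compound 3 gives 310000 nM. Compound 3 therefore sits second highest of the three numbers, and all three lie within the scatter of one another: a 1.4-fold higher number from compound 1 to compound 3 (0.15 log units; within the scatter), a 1.4-fold lower number from compound 2 to compound 3 (0.15 log units; within the scatter) and a 2.0-fold higher number from compound 1 to compound 2 (0.30 log units; within the scatter). Compound 4 `CCOC(=O)c1c(C)[nH]c(=O)c(C#N)c1-c1ccccc1Cl` differs from compound 3 in one place: 2-chlorophenyl in place of 4-bromophenyl on an aromatic carbon. The measured steps cover only the methyl and bromo changes seen in compound 2 and compound 3, none a 2-chlorophenyl group, so the change is only partly covered. As those steps stayed within the scatter, the expected step is a 1.0-fold lower number from compound 3 to compound 4 (0.01 log units; within the scatter). Compound 4 is accordingly estimated at 300000 nM in this assay, with a range from 140000 nM to 650000 nM.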

Compound 4, half-maximal inhibitory concentration: 229000 nM
Beside the measured number, compound 4's estimate is 1.3-fold (0.12 log units) above it, and the stated range covers the measured number.
By their numbers in this assay, from the lowest: compounds 1, 4, 3 and 2 (each within the scatter of the next).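

The aryl group opposite the ring nitrogen now carries a substituent in a second arrangement, as 2-chlorophenyl rather than 4-methylphenyl or 4-bromophenyl. In this assay, this opens no separation, with every new step within the scatter (a 1.0-fold higher number from compound 1 to compound 4 (0.02 log units; within the scatter)) (a 1.4-fold lower number from compound 3 to compound 4 (0.13 log units; within the scatter)) (a 1.9-fold lower number from compound 2 to compound 4 (0.28 log units; within the scatter)). No available evidence bears on this result.

Going by these compounds, whether an amine or a carboxylic acid on this aryl group would move the number beyond the scatter remains open. So does the effect of a longer chain in place of the ethoxycarbonyl group.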